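Working notes: compound 3 in the growth-inhibition series

The compounds below may be only part of what the source reports. "The series", "measured", "known", "first", "only" and "open" are said of these compounds alone.

Measured so far:
compound 1 `Nc1nn(C(=O)Nc2ccc(Cc3ccccc3)cc2)c2ccccc12` — > 100000 nM
compound 2 `Nc1nn(C(=O)Nc2ccc(Cc3ccccc3)cc2)c2ccc(Cl)cc12` — > 100000 nM

Compound 1 `Nc1nn(C(=O)Nc2ccc(Cc3ccccc3)cc2)c2ccccc12` gives only a limit in a functional assay on OVCAR-5 cells (Homo sapiens) for antiproliferative activity, read by sulforhodamine B assay, with a stated time of 48 h (a lower number here means a stronger inhibitor of growth, a higher number a weaker inhibitor of growth), namely > 100000 nM. Compound 2 `Nc1nn(C(=O)Nc2ccc(Cc3ccccc3)cc2)c2ccc(Cl)cc12` likewise gives only a limit in this assay, namely > 100000 nM. The step that the two limits leave unreadable from compound 1 to compound 2 cannot be read from these two values because of the limit of > 100000 nM in this assay, at which 2 of the 2 values shown sit. Compound 2 thus stands at the limit of this assay, with no number of its own.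

Compound 3 `Nc1ccc2c(c1)c(N)nn2C(=O)Nc1ccc(Cc2ccccc2)cc1` differs from compound 2 by amino in place of chloro on an aromatic carbon. For the measured compounds named here, no measured step bears on this change in a readable way: the single measured step in this assay is unreadable, and both measured compounds sit at the limit. Compound 3 is therefore expected to stay at or close to that limit, the expected step that the limit leaves unreadable from compound 2 to compound 3 meaning no change beyond the scatter. For compound 3 the estimate in this assay is 150000 nM, within 40000 nM to 600000 nM.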

Compound 3, concentration for total growth inhibition: 60500 nM
Estimate against measurement, compound 3: 2.5-fold (0.39 log units) above, and the stated range covers the measured number.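

Of the three compounds, only compound 3 gives a number rather than a limit in this assay, so amino on this aromatic carbon is the only group shown here that brings the series into the readable range. The steps are an at least 1.6-fold lower number from compound 2 to compound 3 (0.21 log units; that floor lies within the scatter) and an at least 1.6-fold lower number from compound 1 to compound 3 (0.21 log units; that floor lies within the scatter), and each is a floor rather than a full size. Going by these compounds, the true size of either step stays unknown because compound 1 and compound 2 have no number of their own: the limit of > 100000 nM in this assay, at which 2 of the 3 values shown sit.

On these data alone, whether a methylamino group, a hydroxyl or an acetamide on this carbon would also give a number remains open. So does whether amino on another carbon of this ring would do the same, and how far the value of compound 3 could move with either kind of change.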